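Chain shortening in difluoro- and tetrafluoroalkyl alcohols

The compounds below may be only part of what the source reports. "The series", "measured", "known", "first", "only" and "open" are said of these compounds alone.

Measured compounds:
compound 1, `OCCCCC(F)F`, 0.66
compound 2, `OCCCC(F)F`, 0.29
compound 3, `OCCCC(F)(F)C(F)F`, 0.97

In a physicochemical assay for lipophilicity, read by NMR (on this read-out higher numbers stand for higher lipophilicity and lower numbers for lower lipophilicity), compound 3 stands highest of the three; compound 1 lies nearest and compound 2 furthest. The step of a number 0.68 log units higher from compound 2 to compound 3 (beyond the scatter) goes with difluoromethyl in place of hydrogen on a saturated chain carbon bound to two fluorine atoms and a saturated chain carbon. The step of a number 0.37 log units lower from compound 1 to compound 2 (beyond the scatter) goes with hydroxy in place of hydroxymethyl on a saturated chain carbon, four bonds along the chain from two fluorine atoms. The difference between the cores of compound 1 and compound 3 is not broken down here.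

Compound 4, `OCCC(F)(F)C(F)F`, is not yet measured. It differs from compound 3 by hydroxy in place of hydroxymethyl on a saturated chain carbon, three bonds along the chain from two fluorine atoms. This is the same kind of change as that from compound 1 to compound 2, but the place differs: three bonds along the chain from two fluorine atoms rather than four. Among the compounds with values here, since the only measured instance is a number 0.37 log units lower from compound 1 to compound 2 (beyond the scatter), the step in this assay from compound 3 to compound 4 is expected to be of similar size, a number 0.37 log units lower from compound 3 to compound 4 (beyond the scatter). Compound 4 is therefore estimated at 0.6, with a likely range from 0.35 to 0.85.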

Compound 4, partition coefficient: 0.66
The estimate for compound 4 lay 0.06 log units below the measured number, within the range that was stated.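

In this assay, hydroxy in place of hydroxymethyl gives a number 0.31 log units lower from compound 3 to compound 4 (beyond the scatter), in the same direction as a number 0.37 log units lower from compound 1 to compound 2 (beyond the scatter), so the change carries from the core of compound 1 to the core of compound 3 with its direction kept and both steps printed as modest. Within the data shown here, this rests on only two pairs, and the core and the place differ together between them, three bonds along the chain from two fluorine atoms in one pair and four in the other, so the effect of either cannot be separated and no general rule for other cores follows. No measurement is available that would explain either step.

Open, as far as these compounds go, is whether the same change gives a similar step in a longer chain, or in a chain without fluorine atoms. Also open, from the compounds shown here alone, is how the series reads when an amine or a carboxylic acid stands in place of the hydroxy at the end of the chain.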